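The compounds below may be only part of what the source reports. "The series", "measured", "known", "first", "only" and "open" are said of these compounds alone.

Compound 3 `Cc1ccccc1Oc1ccc(CC2SC(=O)NC2=O)cc1`: 124 nM
Compound 2 `Cc1ccc(C)c(Oc2ccc(CC3SC(=O)NC3=O)cc2)c1`: 238 nM
Compound 1 `O=C1NC(=O)C(Cc2ccc(Oc3ccc(C(F)(F)F)cn3)cc2)S1`: 558 nM

In a functional assay for agonist activity at Free fatty acid receptor 1 (Homo sapiens), read by FLIPR, in the presence of a further agent that is not named here (a higher number here means that more compound is needed for the effect, a lower number that less compound is needed), compound 3 gives the lowest number of the three; compound 2 sits within the scatter of it, while compound 1 lies beyond the scatter. Compound 4 `Cc1ccc(Oc2ccc(CC3SC(=O)NC3=O)cc2)nc1` differs from compound 3 in one place: 5-methylpyridin-2-yl in place of 2-methylphenyl on an oxygen on an aromatic ring. Among the compounds with values here, no measured step covers this change directly. Within the data shown here, the one measured step, a 1.9-fold lower number from compound 2 to compound 3 (0.28 log units; within the scatter), concerns a methyl and does not bear on it. Compound 1, which also carries a pyridine ring on that oxygen but with another substituent, gives 558 nM. On that basis a modest rise is expected, a 2.1-fold higher number from compound 3 to compound 4 (0.32 log units; beyond the scatter), so compound 4 is estimated at 260 nM, within 100 nM to 700 nM.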

Compound 4, half-maximal effective concentration: 4470 nM
Compound 4: middle estimate off by 17-fold (1.24 log units), on the low side; measured number above the stated range.
By their numbers in this assay, from the lowest: compounds 3 and 2 (each within the scatter of the next); then compound 1; then compound 4.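

In this assay, a 36-fold higher number from compound 3 to compound 4 (1.56 log units; beyond the scatter) comes with 5-methylpyridin-2-yl in place of 2-methylphenyl, so this position tolerates the exchange poorly. The group on the pyridine ring also counts: an 8.0-fold higher number from compound 1 to compound 4 (0.90 log units; beyond the scatter) follows from methyl in place of trifluoromethyl on an aromatic carbon. Nothing available explains either step. The ring nitrogen and the methyl placement change together between compound 3 and compound 4, so their shares of the loss cannot be separated. From the compounds shown here alone, how chlorine or methoxy on the pyridine ring would compare also remains open.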